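The compounds below may be only part of what the source reports. "The series", "measured", "known", "first", "only" and "open" are said of these compounds alone.

Working notes on the series, read in a functional assay on MDA-MB-231 cells (Homo sapiens) for antiproliferative activity, read by MTT assay, with a stated time of 72 h; a lower number here means a stronger inhibitor, a higher number a weaker inhibitor. The iodo compound 1 `O=C(CCc1cccc2c1B(O)OC2)Nc1cccc(I)c1` gives 5300 nM, compound 2 `O=C(CCc1cccc2c1B(O)OC2)Nc1cccc(-c2ccc(Cl)cc2)c1` gives 260 nM, and compound 3 `CSc1cccc(-c2cccc(NC(=O)CCc3cccc4c3B(O)OC4)c2)c1` gives 150 nM. Compound 3 therefore sits at the low end of the numbers together with compound 2, within the scatter of it.

The next structure is compound 4 `CSc1ccc(-c2cccc(NC(=O)CCc3cccc4c3B(O)OC4)c2)cc1`, with 4-(methylsulfanyl)phenyl in place of 3-(methylsulfanyl)phenyl on an aromatic carbon, meta to a large group: 4-(methylsulfanyl)phenyl in place of 3-(methylsulfanyl)phenyl on an aromatic carbon.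

The large steps, a 20-fold lower number from compound 1 to compound 2 (1.31 log units; beyond the scatter) and a 35-fold lower number from compound 1 to compound 3 (1.55 log units; beyond the scatter), both remove iodo and say little about this exchange. The closest evidence is a 1.7-fold lower number from compound 2 to compound 3 (0.24 log units; within the scatter), which lies within the scatter although the 4-chlorophenyl and 3-(methylsulfanyl)phenyl groups differ. Among the compounds with values here, no measured pair isolates a move of the methylsulfanyl group alone, so the range stays wide. No change beyond the scatter is expected in this assay. The expected move is a 1.2-fold higher number from compound 3 to compound 4 (0.08 log units; within the scatter). Compound 4 is estimated at 180 nM, with an expected range of 70 nM to 450 nM.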

Compound 4, half-maximal inhibitory concentration: 140 nM
For compound 4 the middle estimate is 1.3-fold (0.11 log units) above the measured one; measured number inside the range.
By their numbers in this assay, from the lowest: compounds 4, 3 and 2 (each within the scatter of the next); then compound 1.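

In this assay the step of a 1.1-fold lower number from compound 3 to compound 4 (0.03 log units; within the scatter) isolates the move of the methylsulfanyl group alone, and 4-(methylsulfanyl)phenyl and 3-(methylsulfanyl)phenyl are not separated at this position. The direct exchange of chloro for methylsulfanyl, a 1.9-fold lower number from compound 2 to compound 4 (0.27 log units; within the scatter) and within the scatter as printed, leaves compounds 2, 3 and 4 as one group, while the step of a 38-fold lower number from compound 1 to compound 4 (1.58 log units; beyond the scatter) in the same assay extends to a third compound the large separation from the iodo compound 1. No measurement at hand accounts for any of these steps.

Open, from the compounds shown here alone, is whether an amine or a carboxylic acid in place of methylsulfanyl on this phenyl ring would stay level with compounds 2, 3 and 4. Also open, going by these compounds, is whether a longer chain on the sulfur would do the same.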